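This account rests on a few compounds, and the source may have more. Where it says the series, first, only, none or still open, it means among the compounds named here.

Among the compounds with values here, compound 3 `CCCC(=O)N1CCC(Sc2c[nH]c3ccc(Cl)cc23)CC1` gives 22.7 mg/kg in a functional assay on the whole organism with Mus musculus as the target, in the hot plate test (on this read-out higher numbers stand for an effect only at larger amounts of compound and lower numbers for an effect already at smaller amounts), the highest number among the three compounds measured so far. Compound 1 `Clc1ccc2[nH]cc(SC3CCNCC3)c2c1`, which carries a bare hydrogen on the amine nitrogen in the ring, gives 1.2 mg/kg, and compound 2 `CC(=O)N1CCC(Sc2c[nH]c3ccc(Cl)cc23)CC1`, with an acetyl there, gives 3.8 mg/kg. The measured steps run a 3.2-fold higher number from compound 1 to compound 2 (0.50 log units; beyond the scatter), a 19-fold higher number from compound 1 to compound 3 (1.28 log units; beyond the scatter) and a 6.0-fold higher number from compound 2 to compound 3 (0.78 log units; beyond the scatter): each attached carbonyl-bearing group raised the number, the longer one more.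

Compound 4 `CCN1CCC(Sc2c[nH]c3ccc(Cl)cc23)CC1` differs from compound 3 by ethyl in place of propylcarbonyl on an amine nitrogen in a ring. Within the data shown here, no measured step swaps an acyl group for a plain alkyl group, so the nearest guidance is compound 1, whose nitrogen also lacks a carbonyl and gives 1.2 mg/kg. Since the rise in the number tracked the carbonyl groups, removing one is expected to bring compound 4 back toward the value of compound 1, with an expected step of an 11-fold lower number from compound 3 to compound 4 (1.05 log units; beyond the scatter) in this assay. Compound 4 is therefore estimated at 2 mg/kg, within a range of 0.7 mg/kg to 6 mg/kg.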

Compound 4, dose for half-maximal effect: 33.3 mg/kg
Beside the measured number, compound 4's estimate is 17-fold (1.22 log units) below it; the measured number lies above the stated range.
By their numbers in this assay, from the lowest: compound 1; then compound 2; then compounds 3 and 4 (each within the scatter of the next).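

In this assay, the carbonyl turns out not to be what decides the number on the amine nitrogen in the ring: ethyl in place of propylcarbonyl leaves compounds that cannot be told apart (a 1.5-fold higher number from compound 3 to compound 4 (0.17 log units; within the scatter)). Ethyl, with no carbonyl at all, still stands far from the bare hydrogen (a 28-fold higher number from compound 1 to compound 4 (1.44 log units; beyond the scatter)) and clearly apart from acetyl (an 8.8-fold higher number from compound 2 to compound 4 (0.94 log units; beyond the scatter)), so among these four compounds the bare hydrogen gives the lowest number, and groups with and without a carbonyl both raise it. Nothing available explains this order.

Left open is whether methyl, a longer chain such as butyl, or benzyl on this nitrogen would fall with ethyl or nearer the bare hydrogen. A chain ending in an amine or a carboxylic acid would test whether every addition here raises the number.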